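The compounds below may be only part of what the source reports. "The series", "measured", "known", "first", "only" and "open" are said of these compounds alone.

Measured in a functional assay on DU-145 cells (Homo sapiens) for antiproliferative activity, read by MTT assay; a higher number here means a weaker inhibitor, a lower number a stronger inhibitor:
compound 1 `Cc1nn2c(-c3nc4cc(Cl)ccc4[nH]3)c(-c3ccccc3)nc2s1` 25100 nM
compound 2 `Cc1ccc2[nH]c(-c3c(-c4ccc(F)cc4)nc4sc(C)nn34)nc2c1` 19900 nM
compound 3 `Cc1ccc(-c2nc3sc(C)nn3c2-c2nc3cc(Cl)ccc3[nH]2)cc1` 7300 nM

Compound 1 and compound 2 carry different cores; the difference between the two cores is not broken down here. Compound 3 relates to compound 1 through (methyl in place of hydrogen on an aromatic carbon), and this change gave a 3.4-fold lower number from compound 1 to compound 3 (0.54 log units; beyond the scatter). Compound 4 `Cc1nn2c(-c3nc4cc(C)c(C)cc4[nH]3)c(-c3ccc(F)cc3)nc2s1` is not yet measured in this assay; it relates to compound 2 through (methyl in place of hydrogen on an aromatic carbon). This is the same kind of change as from compound 1 to compound 3, but the surroundings differ: there the methyl enters para to a large group, here it sits on a ring that is part of a fused or bridged system of two rings, ortho to a methyl group, meta to a fused ring and para to a fused ring. Within the data shown here, only one example of the change exists, so the expectation rests on that single step. Compound 4 is expected to give a smaller step than the earlier one, a 1.7-fold lower number from compound 2 to compound 4 (0.22 log units; within the scatter), because the step from compound 1 to compound 3 was a 3.4-fold lower number from compound 1 to compound 3 (0.54 log units; beyond the scatter) at a different place. Compound 4 is estimated at 12000 nM, likely between 5000 nM and 30000 nM.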

Compound 4, half-maximal inhibitory concentration: > 30000 nM
Compound 4: no number, only a limit; the forecaster's own chance of this, stated with the estimate: 10%; at least 2.5-fold (0.39 log units) between middle value and limit.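

In this assay, methyl in place of hydrogen on an aromatic carbon does not carry over unchanged from one core to the other, with an at least 1.5-fold higher number from compound 2 to compound 4 (0.17 log units; that floor lies within the scatter) running against the earlier step: the same change on two cores in this assay, a 3.4-fold lower number (0.54 log units; beyond the scatter) from compound 1 to compound 3 and an at least 1.5-fold higher number (0.17 log units; that floor lies within the scatter) from compound 2 to compound 4, at least 5.1-fold (0.71 log units) apart, beyond the scatter of two such steps

Compound 4 has only a limit and no number, so the new step gives a floor and not a size: the limit of > 30000 nM in this assay, at which 1 of the 4 values shown sits.

The two steps also sit at different places, so these compounds do not separate the effect of the core from that of the position, and two steps define no rule for the series.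

A methyl at the same place on both cores remains untested in the compounds shown. Going by these compounds, whether an amine or a carboxylic acid on that aromatic carbon would follow either step also stays open.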